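This account rests on a few compounds, and the source may have more. Where it says the series, first, only, none or still open, it means among the compounds named here.

Measured compounds and their results in a functional assay on SR cells (Homo sapiens) for inhibition, read by sulforhodamine B assay, with a stated time of 48 h; a higher number here means a weaker inhibitor of growth, a lower number a stronger inhibitor of growth:

- compound 1, `COc1cc(-c2cc(/C=C/C(=O)c3ccc(N)cc3)[nH]n2)cc(OC)c1OC`, gives 320 nM
- compound 2, `COc1ccc(-c2cc(/C=C/C(=O)c3ccc(OC)c(OC)c3)[nH]n2)cc1`, gives 670 nM
- compound 3, `COc1ccc(-c2cc(/C=C/C(=O)c3ccc(N)cc3)[nH]n2)cc1`, gives 790 nM

Compound 1 has the lowest number of the three, and its gaps to compound 2 and to compound 3 both lie beyond the scatter, so compound 1 is the strongest inhibitor of growth among these three. Compound 2 and compound 3 differ from each other only in the group on the carbonyl carbon, and their two numbers fall within the scatter of each other.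

The unmeasured compound 4, `COc1ccc(C(=O)/C=C/c2cc(-c3cc(OC)c(OC)c(OC)c3)n[nH]2)cc1OC`, is reached from compound 1 by one change: 3,4-dimethoxyphenyl in place of 4-aminophenyl on a carbonyl carbon. The same swap, read from compound 3 to compound 2, left the numbers within the scatter of each other, which suggests that in this assay the step from compound 1 to compound 4 need not go beyond the scatter. On that basis compound 4 is expected to give about 350 nM, with a range from 150 nM to 800 nM, and the expected step from compound 1 to compound 4 is a 1.1-fold higher number from compound 1 to compound 4 (0.04 log units; within the scatter).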

Compound 4, concentration for 50% growth inhibition: 270 nM
Compound 4: middle estimate off by 1.3-fold (0.11 log units), on the high side, and the stated range covers the measured number.
By their numbers in this assay, from the lowest: compounds 4 and 1 (each within the scatter of the next); then compounds 2 and 3 (each within the scatter of the next).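

In this assay, putting 3,4-dimethoxyphenyl in place of 4-aminophenyl on a carbonyl carbon gives a 1.2-fold lower number from compound 1 to compound 4 (0.07 log units; within the scatter) and so leaves the number where it was. Among these compounds, the same swap had been seen only on the other core, where compound 3 gives 790 nM and compound 2 gives 670 nM, also within the scatter, so it has now been seen on two cores with the same outcome. The entering group has more heavy atoms and no hydrogen-bond donor, yet compound 4 stays level with compound 1, so among these compounds a donor on this aryl group is not needed for a number at this level.

From the compounds shown here alone, whether a plain phenyl, a 4-hydroxyphenyl or a carboxylic acid at this place would also hold the number stays open. Nothing measured here bears on why the swap changes so little.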